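Urea series: triazole swap at the benzyl arm

The compounds below may be only part of what the source reports. "The series", "measured", "known", "first", "only" and "open" are said of these compounds alone.

Compound 1 `Cc1cc(C)c(NC(=O)N(Cc2ccc(-c3n[nH]c(C)n3)cc2)C2CCCCCC2)c(C)c1` gives 120 nM in an assay on microsomes from intestine for inhibition of acyl-CoA:cholesterol acyltransferase (Oryctolagus cuniculus) (a higher number here means a weaker inhibitor, a lower number a stronger inhibitor), the higher of the two numbers in hand. Compound 2 `O=C(Nc1c(F)cc(F)cc1F)N(Cc1ccc(-n2cccc2)cc1)C1CCCCCC1` gives 27 nM in this assay, but it differs from compound 1 on both aromatic ends, so no single-change step can be read from it. Compound 3 `Cc1cc(C)c(NC(=O)N(Cc2ccc(-n3nccn3)cc2)C2CCCCCC2)c(C)c1` differs from compound 1 in one place: 2H-1,2,3-triazol-2-yl in place of 5-methyl-1H-1,2,4-triazol-3-yl on an aromatic carbon. Without a measured pair to lean on, the step is expected to be modest, toward a lower number if anything, as a 1.5-fold lower number from compound 1 to compound 3 (0.18 log units; within the scatter) shows. Compound 3 is estimated at 80 nM, in a range from 30 nM to 250 nM.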

Compound 3, half-maximal inhibitory concentration: 130 nM
The estimate for compound 3 lay 1.6-fold (0.21 log units) below the measured number; low and high end bracket the measured number.
By their numbers in this assay, from the lowest: compound 2; then compounds 1 and 3 (each within the scatter of the next).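

At this position, para to a large group, the two triazoles are not told apart in this assay: the swap gives a 1.1-fold higher number from compound 1 to compound 3 (0.03 log units; within the scatter). This holds although the leaving ring has 1 hydrogen-bond donor and the entering ring has 0 hydrogen-bond donors, so a donor on this ring is not required for activity in this pair. No measurement in hand explains the result.

The lower number of compound 2 still cannot be assigned to either of its aromatic ends. As far as these compounds go, an amine or a carboxylic acid at this position remains open.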